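Swapping the aryl ether in a thromboxane synthase inhibitor series

This account rests on a few compounds, and the source may have more. Where it says the series, first, only, none or still open, it means among the compounds named here.

Measured compounds:
Compound 1 `O=C(O)CC/C=C\CC1COC(c2cccs2)OC1c1cccnc1`: 71 nM
Compound 2 `CC(C)(C)c1ccc(OC(C)(C)C2OCC(C/C=C\CCC(=O)O)C(c3cccnc3)O2)cc1`: 280 nM

Both compounds were tested in an assay for inhibition of Thromboxane-A synthase (Homo sapiens), using microsomes; a higher number here means a weaker inhibitor, a lower number a stronger inhibitor. Compound 1 gives 71 nM. Compound 2 gives 280 nM, which is the higher of the two numbers, so compound 2 is the weaker inhibitor of the pair in this assay, and the gap to compound 1 lies beyond the usual scatter of repeated measurements.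

Compound 3 `COc1ccc(OC(C)(C)C2OCC(C/C=C\CCC(=O)O)C(c3cccnc3)O2)c([N+](=O)[O-])c1` has not yet been measured. It keeps the core of compound 2 and differs in one place: 4-methoxy-2-nitrophenyl in place of 4-(tert-butyl)phenyl on an oxygen on a saturated carbon. The ring that enters carries three hydrogen-bond acceptors where the ring that leaves carried none, so the two aryl ethers are quite different in make-up, yet the rest of the molecule is untouched.

Among the compounds with values here, with no measured step of this kind to lean on, the expected step of a 1.1-fold higher number from compound 2 to compound 3 (0.03 log units; within the scatter) is small and within the scatter, in either direction. The value of compound 3 in this assay is therefore estimated at 300 nM, with a plausible range from 100 nM to 900 nM.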

Compound 3, half-maximal inhibitory concentration: 37 nM
Compound 3: the middle estimate sits 8.1-fold (0.91 log units) above what was measured; the measured number lies below the stated range.
By their numbers in this assay, from the lowest: compounds 3 and 1 (each within the scatter of the next); then compound 2.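

Swapping the aryl group of the ether gives, in this assay, a 7.6-fold lower number from compound 2 to compound 3 (0.88 log units; beyond the scatter), so the result in this assay depends on the aryl group at this position even with the rest of the molecule unchanged. Compounds 1 and 2 differ in more than one place and could not isolate this position, but this single-place step also changes several things at once, as the ring that enters carries a methoxy group and a nitro group, with three hydrogen-bond acceptors where the ring that leaves had none. Nothing measured here accounts for the lower number, so its cause remains unknown.

The compounds shown leave open whether the methoxy group, the nitro group or the pair of them goes with the lower number, and a ring carrying only one of the two would help to separate them. As far as these compounds go, it also remains open how a plain phenyl ring, or a ring bearing a chlorine atom, would compare at this position.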